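Notes on the step from compound 2 to compound 3

The compounds below may be only part of what the source reports. "The series", "measured", "known", "first", "only" and "open" are said of these compounds alone.

Measured in a functional assay on Jurkat cells (Homo sapiens); a lower number here means a stronger inhibitor, a higher number a weaker inhibitor:
- compound 1 `CC(C)[C@H](NC(=O)COc1cccc2ccccc12)C(=O)N[C@@H](CC(=O)O)C(=O)COc1ccccc1C(F)(F)F`: limit, > 100000 nM
- compound 2 `CC(C)[C@H](NC(=O)COc1cccc2ccccc12)C(=O)N[C@@H](CC(=O)O)C(=O)COc1ccc(C(F)(F)F)cc1`: limit, > 100000 nM

Compound 2 is known only as a limit (> 100000 nM) and carries no number. Compound 1 likewise gives only a limit (> 100000 nM). Among the measured compounds shown here, the whole series so far rests on one boundary (the limit of > 100000 nM in this assay, at which 2 of the 2 values shown sit).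

Compound 3 `CC(C)[C@H](NC(=O)COc1cccc2ccccc12)C(=O)N[C@@H](CC(=O)O)C(=O)COc1ccc(Oc2ccc(C(F)(F)F)cc2)cc1` differs from compound 2 in one place (4-(trifluoromethyl)phenoxy in place of trifluoromethyl on an aromatic carbon), with 4-(trifluoromethyl)phenoxy in place of trifluoromethyl on an aromatic carbon. For the measured compounds named here, the only measured step that bears on this is a step that the two limits leave unreadable from compound 1 to compound 2, so it offers no size to carry over. No direction is therefore expected, and the expectation stays close to that boundary in this assay. The expected step is an at least 1.2-fold lower number from compound 2 to compound 3 (0.09 log units; that floor lies within the scatter). Compound 3 is estimated at 80000 nM (expected range 15000 nM to 300000 nM).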

Compound 3, half-maximal inhibitory concentration: 9300 nM
Compound 3: the middle estimate sits 8.6-fold (0.93 log units) above what was measured; measured number outside the range, below it.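

In this assay, among the compounds shown here, 4-(trifluoromethyl)phenoxy in place of trifluoromethyl on this aromatic carbon gives an at least 10-fold lower number from compound 2 to compound 3 (1.03 log units; beyond the scatter), the only readable step. Its size is a floor and not an exact figure, because compound 2 is known only as a limit of the assay: the limit of > 100000 nM in this assay, at which 2 of the 3 values shown sit. The step from compound 1 to compound 2 cannot be read, so compound 3 alone shows that a change at this position can bring the series off that boundary.

The compounds shown do not separate the contributions of the oxygen, the added aromatic ring and its trifluoromethyl to this step. From the compounds shown here alone, how a plain phenoxy, a benzyloxy or an amine on the outer ring would read at this position remains open.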